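This account rests on a few compounds, and the source may have more. Where it says the series, first, only, none or still open, it means among the compounds named here.

Working notes on the series, read in a functional assay on A549 cells (Homo sapiens) for antiproliferative activity, read by MTT assay, with a stated time of 72 h; on this read-out higher numbers stand for weaker inhibition and lower numbers for stronger inhibition. Compound 1 `COc1cc2ncnc(Nc3cccc(Br)c3)c2cc1OCCCN1CCNCCNCCNCC1` gives 14700 nM, and compound 2 `COc1cc2ncnc(Nc3ccc(Cl)c(C(F)(F)F)c3)c2cc1OCCCN1CCNCCNCCNCC1` gives 5350 nM. Compound 3 `COc1cccc(Nc2ncnc3cc(OC)c(OCCCN4CCNCCNCCNCC4)cc23)c1` has only a limit, > 50000 nM, so it sits at the weak end of the three without a number of its own. Compound 4 `COc1cc2ncnc(Nc3cccc(F)c3)c2cc1OCCCN1CCNCCNCCNCC1` carries fluoro in place of methoxy on an aromatic carbon, meta to a large group. The closest measured change is an at least 3.4-fold higher number from compound 1 to compound 3 (0.53 log units; beyond the scatter), with methoxy in place of bromo, and an at least 9.3-fold higher number from compound 2 to compound 3 (0.97 log units; beyond the scatter) runs the same way. Read in reverse, these point to a modest step towards a lower number in this assay. The expected step is an at least 2.0-fold lower number from compound 3 to compound 4 (0.30 log units; that floor lies within the scatter). For compound 4 the estimated value is 25000 nM, with an expected range of 11000 nM to 50000 nM.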

Compound 4, half-maximal inhibitory concentration: > 50000 nM
Compound 4: only a limit was reported (the forecaster's own chance of this, stated with the estimate: 20%); middle value at least 2.0-fold (0.30 log units) from the limit.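

Fluoro in place of bromo on an aromatic carbon gives an at least 3.4-fold higher number from compound 1 to compound 4 (0.53 log units; beyond the scatter), and 3-fluorophenyl in place of 4-chloro-3-(trifluoromethyl)phenyl gives an at least 9.3-fold higher number from compound 2 to compound 4 (0.97 log units; beyond the scatter). At this place, then, fluoro does not keep the level seen with bromo, just as methoxy did not. Methoxy and fluoro cannot be ordered, as the step between compound 3 and compound 4 cannot be read with both reported only as a limit: the limit of > 50000 nM in this assay, at which 2 of the 4 values shown sit.

Going by these compounds, how far compound 3 and compound 4 lie past that limit stays open. So does whether iodo or a methyl group at this place would hold the level of compound 1.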